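Swapping the cyclohexyl of compound 3 for a bicyclic urea substituent

The source may report more compounds than this note shows. Statements on the series, on what has been measured and on what is new or still open speak of the compounds shown alone.

Of the compounds shown here, three have been measured in a functional assay on the whole organism (blood) with Rattus norvegicus as the target, with stated times of 24 h and 1 h, at a dose of 5 mg/kg by the intraperitoneal route; on this read-out higher numbers stand for a stronger effect at the one dose given and lower numbers for a weaker effect. Compound 3 `O=C(NC1CCCCC1)NS(=O)(=O)N1CCC(CCNC(=O)c2cccc3cccnc23)CC1` gives 37%, the highest of the three numbers. Among the compounds with values here, compound 1 `Cc1cccc(C(=O)NCCC2CCN(S(=O)(=O)NC(=O)NC[C@@H]3C[C@@H]4C=C[C@@H]3C4)CC2)n1` gives 20%, and compound 2 `COc1ccc2nccc(C(=O)NCCC3CCN(S(=O)(=O)NC(=O)NC[C@@H]4C[C@@H]5C=C[C@@H]4C5)CC3)c2c1` gives 10%; the only single-point step among them, a number 10 percentage points lower from compound 1 to compound 2 (within the scatter), lies within the scatter and concerns the group on the carbonyl carbon, not the urea end.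

Compound 4 `O=C(NC[C@@H]1C[C@@H]2C=C[C@@H]1C2)NS(=O)(=O)N1CCC(CCNC(=O)c2cccc3cccnc23)CC1` keeps the core of compound 3 and differs from it only at the urea nitrogen: a group of 8 heavy atoms (8 carbon; 2 five-membered non-aromatic rings of carbon only) in place of a group of 6 heavy atoms (6 carbon; one six-membered non-aromatic ring of carbon only), on an amide-type nitrogen. Within the data shown here, no measured step bears directly on this exchange. The group that enters is the same one that compounds 1 and 2 carry, and both of those give lower numbers than compound 3 in this assay, but they also differ from compound 3 on the carbonyl carbon, so this comparison is indirect. Compound 4 is therefore expected to show a modest decrease, a number 9 percentage points lower from compound 3 to compound 4 (within the scatter), with wide uncertainty. The estimate for compound 4 is 28%, between 10% and 45%.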

Compound 4, a percentage reported as activity, at one dose (the size of the read-out at that dose, not a potency): 34%
For compound 4 the middle estimate is 6 percentage points below the measured one; the measured number falls inside the stated range.
By their numbers in this assay, from the lowest: compounds 2 and 1 (each within the scatter of the next); then compounds 4 and 3 (each within the scatter of the next).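

In this assay, the exchange at the amide-type nitrogen can now be read directly: the group of 8 heavy atoms in place of cyclohexyl gives a number 3 percentage points lower from compound 3 to compound 4 (within the scatter), so this position does not separate the two groups on this read-out. With that group held constant, quinolin-8-yl on the carbonyl carbon gives a number 24 percentage points higher from compound 2 to compound 4 (beyond the scatter) and a number 14 percentage points higher from compound 1 to compound 4 (beyond the scatter), which places the lower numbers of those two compounds with the change on the carbonyl carbon rather than with the group on the nitrogen. Nothing available explains these steps.

The compounds shown leave open what a methyl group, or a longer chain ending in a carboxylic acid, would do on this nitrogen. They also leave open what the double bond and the three defined stereocentres of the entering group contribute.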